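The compounds below may be only part of what the source reports. "The series", "measured", "known", "first", "only" and "open" are said of these compounds alone.

Working notes on the series

The shared core is carried by compound 1 `Cn1nnnc1SCC(=O)N/N=C/c1ccccc1` and by compound 2 `Cn1nnnc1SCC(=O)N/N=C/c1cccc(F)c1`. In a functional assay on A549 cells (Homo sapiens) for cytotoxicity, read by XTT assay, with a stated time of 24 h (on this read-out higher numbers stand for weaker inhibition and lower numbers for stronger inhibition), compound 1 gives 3160000 nM, and compound 2 gives 6320000 nM. Among the two numbers measured, compound 1 stands at the lowest, with compound 2 nearest to it; the single step of a 2.0-fold higher number from compound 1 to compound 2 (0.30 log units; within the scatter) is the only one measured.

Compound 3 `Cn1nnnc1SCC(=O)N/N=C/c1ccccc1Br` has not been measured in this assay. It differs from compound 1 by bromo in place of hydrogen on an aromatic carbon, the bromo sitting on an aromatic carbon of the six-membered carbon ring, ortho to a large group. Within the data shown here, no measured step changes the same position with the same group, so the nearest guide is the one step in hand, a halogen in place of hydrogen on the same ring, which stayed within the scatter from compound 1 to compound 2.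

On that basis the step of a 1.1-fold higher number from compound 1 to compound 3 (0.04 log units; within the scatter) is expected to stay within the scatter, with no clear direction. Compound 3 is therefore estimated at 3500000 nM in this assay, in the range 1200000 nM to 10000000 nM.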

Compound 3, half-maximal inhibitory concentration: 2000000 nM
Compound 3: middle estimate off by 1.8-fold (0.24 log units), on the high side; the range from low to high includes it.
By their numbers in this assay, from the lowest: compounds 3, 1 and 2 (each within the scatter of the next, the first and the last beyond it).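

A bromo entering on the aromatic ring, ortho to a large group, gives a 1.6-fold lower number from compound 1 to compound 3 (0.20 log units; within the scatter) in this assay, so a halogen at this place leaves compound 3 within the scatter of compound 1. The fluoro change gives a 2.0-fold higher number from compound 1 to compound 2 (0.30 log units; within the scatter), which means that both single halogen changes on this ring now stay within the scatter of compound 1, and neither gives a direction that can be read. Nothing at hand bears on why this bromo change stays within the scatter.

The compounds shown leave open whether an amine, a carboxylic acid or a longer chain at this same place, ortho to a large group, would take the number beyond the scatter of compound 1. They also leave open whether bromo at another place on the ring would behave as it does here, and whether a change to the shared core away from this ring would matter more than either halogen change.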